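This account rests on a few compounds, and the source may have more. Where it says the series, first, only, none or still open, it means among the compounds named here.

Measured so far in an assay on CHO cells for displacement of a labelled ligand from adenosine receptor A3 (Homo sapiens), read by scintillation counting, with a stated time of 45 min, in the presence of a further agent that is not named here; on this read-out lower numbers stand for stronger inhibition and higher numbers for weaker inhibition:
- compound 1 `CCCn1c(=O)[nH]c2nc(-c3ccc(S(=O)(=O)N4CCN(Cc5cccc(Br)c5)CC4)cc3)[nH]c2c1=O` gives > 1000 nM, a limit of the assay.
- compound 2 `CCCn1c(=O)c2[nH]c(-c3ccc(S(=O)(=O)N4CCN(c5ccc(Cl)cc5)CC4)cc3)nc2n(C)c1=O` gives > 1000 nM, also a limit of the assay.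

Compound 1 stands at a limit of this assay and nowhere else on the numbers shown; no inhibition constant for it is known as a number. Within the data shown here, the same holds for compound 2, so there is no measured step between two compounds on which to lean: the limit of > 1000 nM in this assay, at which 2 of the 2 values shown sit.

Compound 3 `CCCn1c(=O)[nH]c2nc(-c3ccc(S(=O)(=O)N4CCN(c5ccccc5)CC4)cc3)[nH]c2c1=O` is not yet measured in this assay. It differs from compound 1 in one place: phenyl in place of 3-bromobenzyl on an amine nitrogen in a ring. Compound 2 carries a 4-chlorophenyl on the same kind of ring nitrogen and sits at the limit as well, so an aryl group directly on the amine nitrogen has not, on the shown values, brought the series below the limit.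

With both shown values at the limit, the step that the limit leaves unreadable from compound 1 to compound 3 cannot be sized from the data and is expected to stay within the scatter, with no direction that can be read off. Compound 3 is expected at 3000 nM, within 800 nM to 20000 nM, most likely reported as a limit again.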

Compound 3, inhibition constant: > 1000 nM
Compound 3 gave a limit, no number (the forecaster's own chance of this, stated with the estimate: 75%); the middle value is on the limit's open side.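

In this assay compound 3 gives > 1000 nM, a limit and not a number. Compound 1 gives > 1000 nM, also a limit, so no step can be read between compound 1 and compound 3: the limit of > 1000 nM in this assay, at which 3 of the 3 values shown sit.

The compounds shown leave open whether any group on the ring amine nitrogen gives a measurable inhibition constant in this assay.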